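The source may hold more compounds than are shown below. What is called first, only, known or untested is meant among the compounds shown, and "the series" means these compounds.

Compound 1 `CN(C)C(=O)c1cc2cnc(Nc3ccc(C(=O)NCCCN=C=S)cc3)nc2n1C1CCCC1` gives 32.9% in a functional assay on A549 cells (Homo sapiens) for inhibition, read by CCK-8 assay, with a stated time of 72 h, tested at 1 uM; a lower number here means a weaker effect, a higher number a stronger effect of the compound at the concentration tested. Among the measured compounds shown here, compound 2 `CN(C)C(=O)c1cc2cnc(Nc3ccc(C(=O)NCCCN=C=S)cc3F)nc2n1C1CCCC1` gives 16.7% in this assay, the lower of the two numbers, and the one step measured so far, a number 16.2 percentage points lower from compound 1 to compound 2 (beyond the scatter), lies beyond the scatter. Compound 3 `CN(C)C(=O)c1cc2cnc(Nc3ccc(C(=O)NCCCCCN=C=S)cc3F)nc2n1C1CCCC1` differs from compound 2 in one place: a group of 5 heavy atoms (3 carbon, 1 nitrogen, 1 sulfur; no ring) in place of a group of 3 heavy atoms (1 carbon, 1 nitrogen, 1 sulfur; no ring), on a saturated chain carbon, three bonds along the chain from an amide-type nitrogen. For the measured compounds named here, the single measured step concerns fluoro in place of hydrogen on an aromatic carbon and does not touch the chain, so no measured step bears on this change. The expected step is therefore a number 1.3 percentage points higher from compound 2 to compound 3 (within the scatter), nothing beyond the scatter. Compound 3 is estimated at 18%, within 5% to 35%.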

Compound 3, a percentage reported as inhibition, at one concentration (the size of the read-out at that concentration, not a potency): -1.6%
Compound 3: the middle estimate sits 19.6 percentage points above what was measured; the measured number lies below the stated range.
By their numbers in this assay, from the lowest: compound 3; then compound 2; then compound 1.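

The chain place, on a saturated chain carbon, three bonds along the chain from an amide-type nitrogen, is sensitive to change: in this assay, the group of 5 heavy atoms in place of the group of 3 heavy atoms gives a number 18.3 percentage points lower from compound 2 to compound 3 (beyond the scatter). Among the compounds shown here, this is the first measured change at this place, and compound 3 stands at -1.6%. No available evidence accounts for this step.

As far as these compounds go, whether the step would recur with hydrogen in place of fluoro stays open. Also open, from the compounds shown here alone, is how a longer chain, an amine or a carboxylic acid at this place would read.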